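Hydroxy on the Diaryl Hydrazone: From Compound 3 to 4

The source may report more compounds than this note shows. Statements on the series, on what has been measured and on what is new or still open speak of the compounds shown alone.

Measured compounds:
compound 1, `COc1ccc(C(=NNc2ccc([N+](=O)[O-])cc2[N+](=O)[O-])c2ccc(OC)cc2O)c(O)c1`: 1.5 ug/mL
compound 2, `O=[N+]([O-])c1ccc(NN=C(c2ccccc2O)c2ccccc2O)c([N+](=O)[O-])c1`: 4.7 ug/mL
compound 3, `O=[N+]([O-])c1ccc(NN=C(c2ccccc2)c2ccccc2)c([N+](=O)[O-])c1`: > 5 ug/mL

In a functional assay on cells (Melanoma tumor cell line, Homo sapiens) for cytotoxicity (on this read-out lower numbers stand for stronger inhibition and higher numbers for weaker inhibition), compound 1 gives 1.5 ug/mL. Compound 2 gives 4.7 ug/mL in this assay. For compound 3 this assay reports only a limit, > 5 ug/mL, so its place among the three is known only as far as the limit of > 5 ug/mL in this assay, at which 1 of the 3 values shown sits; compound 3 sits at the edge of what the assay resolves, without a number of its own.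

Compound 4, `O=[N+]([O-])c1ccc(N/N=C(\c2ccccc2)c2ccc(O)cc2)c([N+](=O)[O-])c1`, is compound 3 carrying (hydroxy in place of hydrogen on an aromatic carbon), on an aromatic carbon of a six-membered aromatic ring of carbon only, para to a large group. Among the compounds with values here, no measured step of this kind exists among the three compounds, so the size of the change is open. Compound 2 and compound 1 carry hydroxy groups and give numbers rather than a limit, which points toward a modest gain for compound 4, though a single hydroxy in this position may leave it near the limit. Compound 4 is therefore expected to give 4.5 ug/mL, in a range from 2.5 ug/mL to 12 ug/mL. The expected step of an at least 1.1-fold lower number from compound 3 to compound 4 (0.04 log units; that floor lies within the scatter) is estimated to be small, toward stronger inhibition, with a real chance that only a limit is returned.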

Compound 4, half-maximal inhibitory concentration: 5 ug/mL
The estimate for compound 4 lay 1.1-fold (0.05 log units) below the measured number; the range from low to high includes it.
By their numbers in this assay, from the lowest: compound 1; then compounds 2 and 4 (each within the scatter of the next).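

In this assay, hydroxy in place of hydrogen on an aromatic carbon, para to a large group, gives a number no higher from compound 3 to compound 4 (the limit leaves the size open). Within the data shown here, this is the first direct view of this change at this place, and compound 4 returns a plain number of 5 ug/mL, so one hydroxy on the ring is enough to yield a number. How much the change moves the value cannot be read, because compound 3 stands only at a limit: the limit of > 5 ug/mL in this assay, at which 1 of the 4 values shown sits.

The compounds shown leave open whether an amine or a carboxylic acid at this same place would give a lower number than compound 4. They also leave open what a hydroxy on the other aromatic ring of compound 4 would do.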